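Furan to Pyridine on the Chain: Expecting Another Limit

The compounds below may be only part of what the source reports. "The series", "measured", "known", "first", "only" and "open" are said of these compounds alone.

Measured so far:
compound 1, `COc1ccc(C(=O)/C=C/c2ccccc2)c2c1C=CC(C)(C)O2`: > 10000 nM
compound 2, `COc1ccc(C(=O)/C=C/c2ccco2)c2c1C=CC(C)(C)O2`: > 10000 nM

In a functional assay on HepG2 cells (Homo sapiens) for antiproliferative activity, read by MTT assay, with a stated time of 24 h (a lower number here means a stronger inhibitor, a higher number a weaker inhibitor), compound 1 gives > 10000 nM, which is a limit of the assay and not a number. Compound 2 gives > 10000 nM in this assay, again a limit. Where compound 2 stands can therefore only be said as a limit, and the one step between the measured compounds, a step that the two limits leave unreadable from compound 1 to compound 2, has no readable size because both of its ends sit at the limit of > 10000 nM in this assay, at which 2 of the 2 values shown sit.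

Compound 3, `COc1ccc(C(=O)/C=C/c2ccccn2)c2c1C=CC(C)(C)O2`, differs from compound 2 by pyridin-2-yl in place of furan-2-yl on a double-bonded chain carbon bound to a double-bonded chain carbon. Among the measured compounds shown here, the only measured step that bears on this change is a step that the two limits leave unreadable from compound 1 to compound 2, another exchange of the ring on that chain carbon, and it gives no size and no direction. Nothing in the numbers shown supports a step beyond the scatter in either direction.

The step that the limit leaves unreadable from compound 2 to compound 3 is accordingly expected to be small. Compound 3 is expected to give 15000 nM in this assay, between 5000 nM and 60000 nM, and most likely to be reported only as a limit.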

Compound 3, half-maximal inhibitory concentration: 5760 nM
Beside the measured number, compound 3's estimate is 2.6-fold (0.42 log units) above it; the range from low to high includes it.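

Among the compounds shown here, with pyridin-2-yl on this chain carbon, compound 3 gives 5760 nM in this assay, the first value in this set that is a real number and not a limit, so a change of ring at this place can bring a compound into the range that the assay can read. Measured against the furan-2-yl ring, the exchange gives an at least 1.7-fold lower number from compound 2 to compound 3 (0.23 log units; that floor lies within the scatter), and measured against the phenyl ring, it gives an at least 1.7-fold lower number from compound 1 to compound 3 (0.23 log units; that floor lies within the scatter). Each of these steps is only a floor, and its true size stays unknown, because one end of each rests on a limit: the limit of > 10000 nM in this assay, at which 2 of the 3 values shown sit.

The compounds shown leave open whether pyridin-3-yl or pyridin-4-yl on this chain carbon would also give a readable number, and so whether the place of the nitrogen in the ring matters. Also open is whether an amine or a carboxylic acid on the pyridin-2-yl ring would shift the result beyond the usual scatter, and nothing shown explains why this ring gives a readable value where furan-2-yl and phenyl give only limits.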